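Ortho-substituted aryl isomers on the oxazole core: solubility notes

The source may report more compounds than this note shows. Statements on the series, on what has been measured and on what is new or still open speak of the compounds shown alone.

Measured so far:
compound 1 `Cc1ccc(C)c(-c2nc(CN3CCC(C(=O)NCCCN4C[C@H](C)C[C@H](C)C4)CC3)c(C)o2)c1` — 56.1 ug/mL
compound 2 `Cc1ccccc1-c1nc(CN2CCC(C(=O)NCCCN3[C@H](C)CCC[C@@H]3C)CC2)c(C)o1` — > 69 ug/mL

Going by the values given here, in a physicochemical assay for solubility, in phosphate buffer, measured as kinetic solubility, at pH 7.4 (a higher number here means a more soluble compound, a lower number a less soluble compound), compound 1 gives 56.1 ug/mL, the only plain number in the set. Compound 2 gives > 69 ug/mL, which is a limit of the assay and not a number (the limit of > 69 ug/mL in this assay, at which 1 of the 2 values shown sits). Compound 3 `CCc1ccccc1-c1nc(CN2CCC(C(=O)NCCCN3C[C@H](C)C[C@H](C)C3)CC2)c(C)o1` is not yet measured. It differs from compound 1 by 2-ethylphenyl in place of 2,5-dimethylphenyl on an aromatic carbon; the two share every atom and the whole remainder of the structure. Among the compounds with values here, no measured step exists for a change of this kind, so no more than scatter is expected. Compound 3 is expected to give 55 ug/mL (range 28 ug/mL to 110 ug/mL), a step of a 1.0-fold lower number from compound 1 to compound 3 (0.01 log units; within the scatter) within the scatter.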

Compound 3, solubility: 55.9 ug/mL
For compound 3 the middle estimate is 1.0-fold (0.01 log units) below the measured one; the measured number falls inside the stated range.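

In this assay, going by these compounds alone, 2-ethylphenyl in place of 2,5-dimethylphenyl gives a 1.0-fold lower number from compound 1 to compound 3 (0.00 log units; within the scatter), the first step that can be read at this position. For this pair, rearranging the same carbon atoms around the aromatic ring leaves the read-out inside the scatter. Nothing measured here gives a cause for this step.

As far as these compounds go, whether an amine or a carboxylic acid on this phenyl ring would shift the read-out remains open. Compound 2 stands at > 69 ug/mL, a limit of the assay and not a number, and it differs from the other two compounds in more than one place.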